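From Cyclohexyl to Piperidin-4-yl on the Shared Core

The source may report more compounds than this note shows. Statements on the series, on what has been measured and on what is new or still open speak of the compounds shown alone.

Of the compounds shown here, three sharing one core have been measured in a functional assay on cells (Homo sapiens), read by thymidine incorporation; on this read-out higher numbers stand for weaker inhibition and lower numbers for stronger inhibition. Going by the values given here, there, compound 1 (`CCOC(=O)c1cc(NCc2cccnc2)n2ncc(Br)c2n1`) gives 2900 nM, compound 2 (`Clc1ccccc1-c1cc(NCc2cccnc2)n2ncc(Br)c2n1`) gives 500 nM; 500 nM (2 entries) in both of its entries, and compound 3 (`Brc1cnn2c(NCc3cccnc3)cc(C3CCCCC3)nc12`) gives 200 nM, the lowest number of the series so far. The next compound, compound 4 (`Brc1cnn2c(NCc3cccnc3)cc(C3CCNCC3)nc12`), has piperidin-4-yl in place of cyclohexyl on an aromatic carbon.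

Among the compounds with values here, only one measured step bears on this change. At the same aromatic carbon, cyclohexyl in place of ethoxycarbonyl gives a 15-fold lower number from compound 1 to compound 3 (1.16 log units; beyond the scatter), a large step beyond the scatter. It shows that the number in this assay can respond strongly to the group at this carbon. However, that step swaps a very different group, whereas the new change keeps the six-membered ring and its size. Within the data shown here, no measured pair tests a ring nitrogen of this kind, so the direction rests on little evidence. A small rise is expected, and the expected step, not beyond the scatter, is a 1.5-fold higher number from compound 3 to compound 4 (0.18 log units; within the scatter). For compound 4 the estimated value is 300 nM, with an expected range from 60 nM to 1500 nM.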

Compound 4, half-maximal inhibitory concentration: 160 nM
Compound 4: middle estimate off by 1.9-fold (0.27 log units), on the high side, within the range that was stated.
By their numbers in this assay, from the lowest: compounds 4 and 3 (each within the scatter of the next); then compound 1.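

In this assay, going by these compounds alone, piperidin-4-yl in place of cyclohexyl gives a 1.3-fold lower number from compound 3 to compound 4 (0.10 log units; within the scatter), so at this carbon a ring nitrogen, with the hydrogen-bond donor and acceptor counted for it, can enter the six-membered ring without the number moving beyond the scatter, something no earlier compound could show. The large step away from the ethoxycarbonyl group is also not tied to the all-carbon ring: alongside a 15-fold lower number from compound 1 to compound 3 (1.16 log units; beyond the scatter) there now stands an 18-fold lower number from compound 1 to compound 4 (1.26 log units; beyond the scatter), so both six-membered non-aromatic rings lie far from compound 1 on this read-out. Nothing measured here bears on the reason for this result.

The compounds shown leave open how the number would respond at this carbon to a piperidin-4-yl ring carrying a methyl or acetyl group on its nitrogen, to a morpholine ring, or to an open-chain amine. As far as these compounds go, it also remains open whether the match between cyclohexyl and piperidin-4-yl would hold if the bromine on the shared core gave way to a chlorine or a nitrile.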